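Phenyl for methyl on compound 3: expected potency

The source may hold more compounds than are shown below. What is called first, only, known or untested is meant among the compounds shown, and "the series" means these compounds.

The series is tested in a functional assay on SK-N-SH cells (Homo sapiens) for antiproliferative activity, read by MTT assay, with a stated time of 48 h; on this read-out higher numbers stand for weaker inhibition and lower numbers for stronger inhibition. Compound 1 `Cc1oc2c3c(ccc2c(=O)c1C)OC[C@H]1[C@@H]3C2=C(CCCC2=O)OC1(C)C` gives > 100000 nM, which is a limit of the assay and not a number. Compound 2 `Cc1oc2c3c(ccc2c(=O)c1-c1ccccc1)OC[C@H]1[C@@H]3C2=C(CCCC2=O)OC1(C)C` likewise gives > 100000 nM, again a limit. The step that the two limits leave unreadable from compound 1 to compound 2 cannot be read, both ends sitting at the limit of > 100000 nM in this assay, at which 2 of the 3 values shown sit. Among the compounds with values here, compound 3 `Cc1nn(-c2ccccc2)c2c1[C@@H]1c3c(ccc4c(=O)c(C)c(C)oc34)OC[C@@H]1C(C)(C)O2` is the only member with a measured number, 10600 nM, and so stands alone as the single readable point of the set.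

Compound 4 `Cc1nn(-c2ccccc2)c2c1[C@@H]1c3c(ccc4c(=O)c(-c5ccccc5)c(C)oc34)OC[C@@H]1C(C)(C)O2` carries the change (phenyl in place of methyl on an aromatic carbon). Within the data shown here, the same exchange, phenyl in place of methyl on an aromatic carbon, was made from compound 1 to compound 2, but with both values at the limit its size is not readable, so no measured step bears on the present change. Given only compound 3 with 10600 nM to draw on, the step to compound 4 is expected to stay within the scatter, a 1.4-fold higher number from compound 3 to compound 4 (0.15 log units; within the scatter). A wide range is kept because compound 1 and compound 2 sit at the limit of > 100000 nM in this assay, at which 2 of the 3 values shown sit, which shows that members of this set can fall to the limit. Compound 4 is estimated at 15000 nM, between 4000 nM and 70000 nM.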

Compound 4, half-maximal inhibitory concentration: > 100000 nM
Compound 4 was reported as a limit; the forecaster's own chance of this, stated with the estimate: 30%; middle value at least 6.6-fold (0.82 log units) away from the limit.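

In this assay, phenyl in place of methyl at this position, on an aromatic carbon ortho to a methyl group and two atoms from the ring oxygen, now has a readable effect: an at least 9.4-fold higher number from compound 3 to compound 4 (0.97 log units; beyond the scatter). The same exchange between compound 1 and compound 2 cannot be read, with both ends at the limit, whereas here it removes the only measurable activity among the compounds shown, the activity of compound 3. Compound 4 gives > 100000 nM, a limit of the assay and not a number, so the step sets only a lower bound on the loss, and the set now gathers at one end of the read-out: the limit of > 100000 nM in this assay, at which 3 of the 4 values shown sit.

Within the data shown here, what an ethyl group, a methoxy group or an amine at this position would do to the activity of compound 3 stays open, so it cannot be said whether methyl is the only group here that keeps a measurable value. Also open, as far as these compounds go, is whether a group on the phenyl ring, such as a hydroxyl or a carboxylic acid, would bring compound 4 back into the measurable range.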